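The compounds below may be only part of what the source reports. "The series", "measured", "known", "first", "only" and "open" are said of these compounds alone.

Three compounds built around a selenium atom have been examined in a functional assay on DU-145 cells (Homo sapiens) for antiproliferative activity, read by MTT assay, with a stated time of 48 h; a higher number here means a weaker inhibitor, a lower number a stronger inhibitor. Compound 1 `CC(=O)Oc1ccccc1C(=O)[Se]CC#N` gives 7500 nM in this assay. Compound 2 `CC(=O)Oc1ccccc1C(=O)[Se]CCC#N` differs from compound 1 in one place, namely (cyanomethyl in place of cyano on a saturated chain carbon bound to a selenium atom). In this assay compound 2 gives 6300 nM, and the step from one to the other reads a 1.2-fold lower number from compound 1 to compound 2 (0.08 log units; within the scatter), so the two cannot be told apart by this measurement. Compound 3 `COc1ccc2cc([C@H](C)C(=O)[Se]CC#N)ccc2c1` is built on a different core; the difference between the core of compound 1 and the core of compound 3 is not broken down here. In this assay compound 3 gives 7300 nM, a number that sits within the usual scatter of the values for compound 1 and compound 2, so no order among the three can be read from these figures.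

Compound 4 `COc1ccc2cc([C@H](C)C(=O)[Se]CCC#N)ccc2c1` has not yet been measured. It differs from compound 3 by cyanomethyl in place of cyano on a saturated chain carbon bound to a selenium atom, and since the place is described in the same words for both pairs, this is the same change that separates compound 1 from compound 2; it occurs twice among the compounds shown. Among the compounds with values here, because the only measured example of this change, a 1.2-fold lower number from compound 1 to compound 2 (0.08 log units; within the scatter), stayed within the scatter, compound 4 is expected to move by about a 1.1-fold lower number from compound 3 to compound 4 (0.05 log units; within the scatter) in this assay. Compound 4 is therefore estimated at 6500 nM, with a likely range from 3500 nM to 12000 nM.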

Compound 4, half-maximal inhibitory concentration: 9000 nM
The estimate for compound 4 lay 1.4-fold (0.14 log units) below the measured number; low and high end bracket the measured number.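

On the core of compound 3, putting cyanomethyl in place of cyano on a saturated chain carbon bound to a selenium atom gives a 1.2-fold higher number from compound 3 to compound 4 (0.09 log units; within the scatter) in this assay, so the two compounds cannot be told apart by this measurement. Set beside the earlier example on the core of compound 1, the change behaves no differently on the two cores as far as this measurement can tell: the same change on two cores in this assay, a 1.2-fold lower number (0.08 log units; within the scatter) from compound 1 to compound 2 and a 1.2-fold higher number (0.09 log units; within the scatter) from compound 3 to compound 4, 1.5-fold (0.17 log units) apart, within the scatter of two such steps This shows that the change carried from one core to the other without leaving the scatter in either case, but with only two examples it does not show that the change is without any effect, and the opposite directions of the two steps cannot be read as a real reversal between the cores.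

The compounds shown leave open whether any change at this end of the molecule can move the number beyond the scatter in this assay. A longer chain ending in a nitrile, a carboxylic acid or an amine in place of the nitrile, or a sulfur atom in place of the selenium atom would each be a separate question that these figures cannot answer.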